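The source may hold more compounds than are shown below. What is called first, only, known or untested is meant among the compounds shown, and "the series" means these compounds.

The measured compounds:

Compound 1, `COc1cccc(C2=NNC(c3ccc(Cl)cc3)C2O)c1`, 49 nM
Compound 2, `COc1cccc(C2=NNC(c3ccc(Br)cc3)C2O)c1`, 49 nM
Compound 3, `COc1ccc(C(=O)C2OC2c2ccc(Cl)cc2)cc1`, 26 nM

All three were tested in a functional assay on MCF7 cells (Homo sapiens) for antiproliferative activity, read by sulforhodamine B assay, with a stated time of 48 h; on this read-out lower numbers stand for stronger inhibition and higher numbers for weaker inhibition. Compound 1 and compound 2 share one core and differ only in bromo in place of chloro on an aromatic carbon; this change produced no change at the digits printed from compound 1 to compound 2 (within the scatter). Compound 3 is built on a different core, and how its core differs from that of compound 1 is not broken down here; the numbers alone show that compound 3 and compound 1 sit within the scatter of each other in this assay, as do compound 3 and compound 2.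

Compound 4, `COc1ccc(C(=O)C2OC2c2ccc(Br)cc2)cc1`, is not yet measured. It is related to compound 3 by bromo in place of chloro on an aromatic carbon, which is the same change as that made from compound 1 to compound 2, at a place described in the same words. Since the earlier instance gave no change at the digits printed from compound 1 to compound 2 (within the scatter), the expectation for the new pair is no change at the digits printed from compound 3 to compound 4 (within the scatter) in this assay, resting on that single precedent; whether the second core responds in the same way is exactly what the measurement will show. On this basis compound 4 is estimated at 26 nM, with a likely range from 12 nM to 55 nM.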

Compound 4, half-maximal inhibitory concentration: 13 nM
For compound 4 the middle estimate is 2.0-fold (0.30 log units) above the measured one; the range from low to high includes it.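

In this assay, bromo in place of chloro on an aromatic carbon gave a 2.0-fold lower number from compound 3 to compound 4 (0.30 log units; within the scatter) on the second core, so on this core, as on the first, the step stays within the usual scatter of repeated measurements. This shows that, in these two pairs, the change carried from one core to the other without a step beyond the scatter, but two pairs tested in a single assay cannot establish a rule for the series, and they do not show that the two cores respond identically, since steps this small cannot separate a real difference from the scatter. Set side by side, the two instances give no reason to treat the cores as different for this change: the same change on two cores in this assay, no change at the digits printed (within the scatter) from compound 1 to compound 2 and a 2.0-fold lower number (0.30 log units; within the scatter) from compound 3 to compound 4, 2.0-fold (0.30 log units) apart, within the scatter of two such steps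

The compounds shown carry only chloro or bromo at this place, which leaves open how fluoro, iodo, methyl or trifluoromethyl would read there on either core, and whether an amine or a carboxylic acid at the same carbon would keep the values in the same region. They also leave open whether the methoxy group on the other aromatic ring can be exchanged for a hydroxyl or a longer chain such as ethoxy, and whether the bromo and chloro pairs would stay this close on any third core.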